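A few compounds are considered here, and "the series" means these few. Any claim that something is new, unique, unknown or untested is made for them only; others in the source may bear on it.

Compound 1 `COc1cc(N2C(N)=C(C#N)C(c3c(O)ccc4ccccc34)C3=C2CC(C)(C)CC3=O)cc(OC)c1OC` gives 15% in a functional assay on Ehrlich cells (Mus musculus) for cytotoxicity, tested at 50 ug/mL; on this read-out higher numbers stand for a stronger effect at the one concentration tested and lower numbers for a weaker effect. Compound 2 `COc1cc(N2C(N)=C(C#N)C(c3ccc([N+](=O)[O-])cc3)C3=C2CC(C)(C)CC3=O)cc(OC)c1OC` gives 70%. Compound 3 `COc1cc(N2C(N)=C(C#N)C(c3cccs3)C3=C2CC(C)(C)CC3=O)cc(OC)c1OC` gives 15%.

On these numbers compound 2 stands highest of the three, with compound 1 and compound 3 both well below it. Compound 4 `COc1ccc(C2C(C#N)=C(N)N(c3cc(OC)c(OC)c(OC)c3)C3=C2C(=O)CC(C)(C)C3)cc1` differs from compound 2 in one place: methoxy in place of nitro on an aromatic carbon. Among the measured compounds shown here, no measured step swaps nitro for methoxy directly, so the nearest guides are the two steps that leave compound 2: a number 55 percentage points higher from compound 1 to compound 2 (beyond the scatter) and a number 55 percentage points lower from compound 2 to compound 3 (beyond the scatter). Both are large, and both show the nitro-bearing compound 2 standing apart from its two companions. A large downward step in this assay is therefore expected, its exact size uncertain. Compound 4 is expected to give 25%, between 10% and 50%, that is a number 45 percentage points lower from compound 2 to compound 4 (beyond the scatter).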

Compound 4, a percentage reported as activity, at one concentration (the size of the read-out at that concentration, not a potency): 11%
Compound 4: middle estimate off by 14 percentage points, on the high side; measured number inside the range.
By their numbers in this assay, from the lowest: compounds 4, 1 and 3 (each within the scatter of the next); then compound 2.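

In this assay, replacing nitro with methoxy on the same aromatic carbon gives a number 59 percentage points lower from compound 2 to compound 4 (beyond the scatter), so a phenyl ring at this place is not enough on its own to keep the high number of compound 2. The 4-methoxyphenyl group cannot be told apart from the other two groups, with a number 4 percentage points lower from compound 3 to compound 4 (within the scatter) and a number 4 percentage points lower from compound 1 to compound 4 (within the scatter). No measurement shown gives a reason for the drop.

The compounds shown leave open whether nitro is the only group that keeps the high number. A 4-aminophenyl or 4-chlorophenyl group could fall on either side.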